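The compounds below may be only part of what the source reports. "The series", "measured", "known", "first", "only" and "open" are said of these compounds alone.

Three compounds have been measured in a functional assay on a cell-free system (plasma) for agonist activity at thromboxane A2 receptor (Homo sapiens); a lower number here means a stronger inhibitor, a higher number a weaker inhibitor:

Compound 1 `O=C(O)COC/C=C1\C[C@H]2C[C@@H](O)[C@H](/C=N/NC(=O)Nc3ccccc3)[C@H]2C1` gives 6000 nM.
Compound 2 `O=C(O)CCC/C=C1/C[C@H]2CC[C@H](/C=N/NC(=O)Nc3ccc(Cl)c(Cl)c3)[C@H]2C1` gives 1800 nM.
Compound 3 `O=C(O)CCC/C=C1\C[C@H]2CC[C@H](/C=N/NC(=O)Nc3ccc(Cl)c(Cl)c3)[C@H]2C1` gives 9000 nM.

Compound 3 carries the highest of the three numbers. Compound 1 lies nearest to it, within the scatter, and compound 2 lies furthest from it. Among the measured compounds shown here, the only measured step between compounds that differ in one place is a 5.0-fold higher number from compound 2 to compound 3 (0.70 log units; beyond the scatter), a step that rests on the fact that compounds 2 and 3 differ only in the configuration as drawn and concerns the drawn configuration of the shared core, not the aromatic substituent.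

Compound 4 `O=C(O)CCC/C=C1\C[C@H]2CC[C@H](/C=N/NC(=O)Nc3cccc(Cl)c3)[C@H]2C1` differs from compound 3 by hydrogen in place of chloro on an aromatic carbon. For the measured compounds named here, none of the measured steps bears on that change: the one step known, between compound 2 and compound 3, touches a different part of the molecule, and no measured pair differs only in the chloro pattern of the aromatic ring. For compound 4 the expected step is therefore a 1.3-fold higher number from compound 3 to compound 4 (0.12 log units; within the scatter), that is, no change beyond the scatter. The estimate for compound 4 in this assay is 12000 nM, with a range from 4000 nM to 40000 nM.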

Compound 4, half-maximal inhibitory concentration: 6500 nM
The estimate for compound 4 lay 1.8-fold (0.27 log units) above the measured number; the range from low to high includes it.
By their numbers in this assay, from the lowest: compound 2; then compounds 1, 4 and 3 (each within the scatter of the next).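

Replacing the 3,4-dichlorophenyl group with the 3-chlorophenyl group, a change on the aromatic carbon ortho to a chloro group and para to a large group, gives a 1.4-fold lower number from compound 3 to compound 4 (0.14 log units; within the scatter) in this assay. Among the compounds shown here, this is the first measured step on the aromatic ring, and it shows that, with the double bond drawn E, chloro and hydrogen at this position cannot be told apart in this assay. Nothing given here explains this result, since the only known difference in configuration concerns another part of the molecule.

On these data alone, whether the same exchange would read alike with the double bond drawn Z, as in compound 2, stays open. So does what a fluoro, methoxy or amino group would do at this position.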